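The source may report more compounds than this note shows. Statements on the series, on what has been measured and on what is new or still open speak of the compounds shown alone.

In a functional assay on PC-3 cells (Homo sapiens) for antiproliferative activity, read by MTT assay, with a stated time of 72 h (on this read-out lower numbers stand for stronger inhibition and higher numbers for weaker inhibition), compound 1 (`CN(C)CCn1cccc1/C=N/NC(=O)Nc1ccc(Oc2ccnc3[nH]ccc23)c(F)c1`) gives 1600 nM and compound 2 (`CN1CCN(CCCn2cccc2/C=N/NC(=O)Nc2ccc(Oc3ccnc4[nH]ccc34)c(F)c2)CC1`) gives 2190 nM while compound 3 (`O=C(N/N=C/c1cccn1CCCN1CCCC1)Nc1ccc(Oc2ccnc3[nH]ccc23)c(F)c1`) gives 3580 nM in the same range. Among the measured compounds shown here, compound 3 separates from only one neighbour: the steps are a 1.6-fold higher number from compound 2 to compound 3 (0.21 log units; within the scatter) and a 2.2-fold higher number from compound 1 to compound 3 (0.35 log units; beyond the scatter) against a 1.4-fold higher number from compound 1 to compound 2 (0.14 log units; within the scatter) for the remaining pair. Compound 4 (`O=C(N/N=C/c1cccn1CCCN1CCCC1)Nc1ccc(Oc2ccnc3[nH]ccc23)cc1`) changes one place: hydrogen in place of fluoro on an aromatic carbon. All measured steps alter the chain end and none touches this place, so they offer only a rough size for single changes. Starting from compound 3 at 3580 nM no step beyond the scatter is expected in this assay in either direction. The expected step is a 1.1-fold higher number from compound 3 to compound 4 (0.03 log units; within the scatter) on this estimate. For compound 4 the estimated value is 3800 nM with an expected range of 1600 nM to 9000 nM in this series.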

Compound 4, half-maximal inhibitory concentration: 4290 nM
Compound 4: middle estimate off by 1.1-fold (0.05 log units), on the low side, and the stated range covers the measured number.
By their numbers in this assay, from the lowest: compounds 1, 2, 3 and 4 (each within the scatter of the next, the first and the last beyond it).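

Hydrogen in place of fluoro, on an aromatic carbon ortho to a large group and meta to a large group, gives a 1.2-fold higher number from compound 3 to compound 4 (0.08 log units; within the scatter) in this assay. Among the compounds shown here, this is the first reading at this place, as the earlier steps all altered the chain end, and with the pyrrolidin-1-yl chain end the two compounds cannot be told apart here. No available measurement bears on the reason for this result.

Open, going by these compounds, is whether chloro or methoxy on this aromatic carbon would read the same. Also open, on these data alone, is whether the same exchange stays as small with a dimethylamino or 4-methylpiperazin-1-yl chain end.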